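This account rests on a few compounds, and the source may have more. Where it says the series, first, only, none or still open, it means among the compounds named here.

Compound 1, `CC#C[C@H]1CN(S(=O)(=O)c2ccc(N)nc2)CCN1c1ccc(S(=O)(=O)NC)cn1`, gives 381 nM in an assay on cells (Hepatocyte) for inhibition of glucokinase regulatory protein (Mus musculus), with stated times of 20 min and 40 min; a higher number here means that more compound is needed for the effect, a lower number that less compound is needed.
Compound 2, `CC#C[C@H]1CN(S(=O)(=O)c2ccc(N)nc2)CCN1c1ncc(C(C)(O)C(F)(F)F)s1`, gives in this assay only a limit, > 12500 nM.
Compound 3, `CC#C[C@H]1CN(S(=O)(=O)c2ccc(N)nc2)CCN1c1ccc(S(=O)(=O)NCC2CC2)cc1`, gives 271 nM in this assay.

Of the two results that are real numbers, compound 3 has the lowest, but compound 1 sits within the usual scatter of it, so the two cannot be told apart. Compound 2 reaches only (the limit of > 12500 nM in this assay, at which 1 of the 3 values shown sits), meaning the assay reported no number for it.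

The next compound, compound 4, `CC#C[C@H]1CN(S(=O)(=O)c2ccc(N)nc2)CCN1c1ccc(C(=O)NC)cc1`, differs from compound 3 in one place: methylcarbamoyl in place of (cyclopropylmethyl)sulfamoyl on an aromatic carbon. For the measured compounds named here, no measured pair among the three compounds shows exactly this exchange, so there is no direct precedent for its size. What the data do show is that compound 1 and compound 3, which carry different groups on that part of the molecule, land within the scatter of one another. On that basis the step from compound 3 to compound 4 is expected to be modest, probably toward a somewhat higher number, a 2.2-fold higher number from compound 3 to compound 4 (0.35 log units; beyond the scatter). Compound 4 is therefore estimated at 600 nM in this assay, with a likely range from 200 nM to 2000 nM.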

Compound 4, half-maximal effective concentration: 4050 nM
For compound 4 the middle estimate is 6.8-fold (0.83 log units) below the measured one; the whole stated range lies below it.
By their numbers in this assay, from the lowest: compounds 3 and 1 (each within the scatter of the next); then compound 4. At a limit, above all of these: compound 2.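

The exchange of (cyclopropylmethyl)sulfamoyl for methylcarbamoyl on this aromatic carbon, para to a large group, is the first change in a single place among these compounds, and in this assay it gives a 15-fold higher number from compound 3 to compound 4 (1.17 log units; beyond the scatter). This shows that the number in this assay depends strongly on what sits at this place, even though the hydrogen-bond donor count stays the same: the leaving group has 8 heavy atoms and a three-membered ring, while the entering group has 4 heavy atoms and no ring. The data shown offer no measurement that explains the size of this step.

The exchange alters both the sulfonyl-to-carbonyl link and the chain on the nitrogen, so the compounds shown cannot say which of the two matters more; a (cyclopropylmethyl)carbamoyl group on the same aromatic carbon would separate them. Also open, on these data alone, is how this place responds to groups of another kind, such as a carboxylic acid or an amine.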